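A few compounds are considered here, and "the series" means these few. Any claim that something is new, unique, unknown or untested is made for them only; others in the source may bear on it.

Measured in a functional assay on the whole organism (strain Kunming) with Mus musculus as the target, with a stated time of 0.5 h, at a dose of 300 mg/kg by the intraperitoneal route; on this read-out lower numbers stand for a stronger effect and higher numbers for a weaker effect at the one dose given:
compound 1 `COc1cc(OC)c(OC)cc1/C=C/COC(=O)/C=C/c1ccc(OC)c(OC)c1` gives 100%
compound 2 `COc1cc(OC)c(OC)cc1/C=C/COC(=O)/C=C/c1ccc(F)cc1` gives 100%
compound 3 `COc1cccc(/C=C/C(=O)OC/C=C/c2cc(OC)c(OC)cc2OC)c1` gives 100%

Compound 1 stands level with compounds 2 and 3 in this assay; the steps of no change at the digits printed from compound 1 to compound 2 (within the scatter), no change at the digits printed from compound 1 to compound 3 (within the scatter) and no change at the digits printed from compound 2 to compound 3 (within the scatter) all fall within the scatter. Compound 4 `COc1cc(OC)c(OC)cc1/C=C/COC(=O)/C=C/c1cc(OC)c(OC)c(OC)c1` is not yet measured. It differs from compound 1 by methoxy in place of hydrogen on an aromatic carbon, the entering group sitting ortho to a methoxy group and meta to a large group. The three measured steps all alter the same aryl end of the ester and none moves the read-out, so no step beyond the scatter is expected here in this assay: the estimated step is no change at the digits printed from compound 1 to compound 4 (within the scatter). Compound 4 is accordingly expected to give 100%, with a range of 88% to 100%.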

Compound 4, a percentage reported as activity, at one dose (the size of the read-out at that dose, not a potency): 100%
The estimate for compound 4 equals the measured number at the digits printed; low and high end bracket the measured number.
By their numbers in this assay, from the lowest: compounds 1, 2, 3 and 4 (each within the scatter of the next).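

In this assay, methoxy in place of hydrogen on an aromatic carbon, ortho to a methoxy group and meta to a large group, gives no change at the digits printed from compound 1 to compound 4 (within the scatter). The earlier steps shown here removed or exchanged groups on this aryl end, whereas this one adds a group to the ring of compound 1 and still leaves the read-out flat. No measurement on hand accounts for this result.

With all four compounds level, the series offers no spread against which to rank this position. From the compounds shown here alone, whether an amine or a carboxylic acid on this ring, or an amide in place of the ester, would move the read-out remains open.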